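Working notes: exchanging the whole pendant ring on the shared core

The source may report more compounds than this note shows. Statements on the series, on what has been measured and on what is new or still open speak of the compounds shown alone.

Compound 1 `Cc1ccnc(-c2cnc(C(=O)CCCCCCc3ccccc3)o2)c1` gives 1 nM in an assay (Rattus norvegicus) for inhibition of Fatty-acid amide hydrolase 1 (Homo sapiens); on this read-out higher numbers stand for weaker inhibition and lower numbers for stronger inhibition. Among the measured compounds shown here, compound 2 `COc1ccnc(-c2cnc(C(=O)CCCCCCc3ccccc3)o2)c1` gives 1.7 nM in this assay; of the two numbers so far it stands highest, with compound 1 nearest, and the step of a 1.7-fold higher number from compound 1 to compound 2 (0.23 log units; within the scatter) lies within the scatter. Compound 3 `O=C(CCCCCCc1ccccc1)c1ncc(-c2cc(=O)[nH]c(=O)[nH]2)o1` is not yet measured. It differs from compound 2 by a group of 8 heavy atoms (4 carbon, 2 nitrogen, 2 oxygen; one six-membered aromatic ring with 2 hetero atoms) in place of a group of 8 heavy atoms (6 carbon, 1 nitrogen, 1 oxygen; one six-membered aromatic ring with 1 hetero atom), on an aromatic carbon. For the measured compounds named here, the only measured step, a 1.7-fold higher number from compound 1 to compound 2 (0.23 log units; within the scatter), swaps one small substituent for another and does not bear on exchanging the whole ring; no measured step speaks to this change, so its direction is open. Compound 3 is therefore estimated at 20 nM, with a range of 2 nM to 200 nM, an expected step of a 12-fold higher number from compound 2 to compound 3 (1.07 log units; beyond the scatter) held only loosely.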

Compound 3, half-maximal inhibitory concentration: 5 nM
Compound 3: middle estimate off by 4.0-fold (0.60 log units), on the high side; the range from low to high includes it.
By their numbers in this assay, from the lowest: compounds 1 and 2 (each within the scatter of the next); then compound 3.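

Exchanging the whole pendant ring on this aromatic carbon of the five-membered ring moves the number beyond the scatter in this assay, but only modestly (a 2.9-fold higher number from compound 2 to compound 3 (0.47 log units; beyond the scatter); a 5.0-fold higher number from compound 1 to compound 3 (0.70 log units; beyond the scatter)). A ring with 2 hydrogen-bond donors and 2 double bonds outside aromatic rings is therefore accepted here in place of rings with no donors, at a modest cost. Nothing measured for these compounds accounts for this step.

As far as these compounds go, whether a pendant ring carrying a carboxylic acid or an amine would stay this close remains open. So does whether one hydrogen-bond donor on the ring, rather than 2, would give a smaller step.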